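Methyl for Bromo: Cytotoxicity of Four Related Compounds

The compounds below may be only part of what the source reports. "The series", "measured", "known", "first", "only" and "open" are said of these compounds alone.

Measured compounds:
Compound 1 `CC(=O)OC[C@H]1O[C@@H](n2c(SCc3cc4cc(Br)ccc4oc3=O)nc3cncnc32)[C@H](OC(C)=O)[C@@H]1OC(C)=O` gives 6700 nM.
Compound 2 `CC(=O)OC[C@H]1O[C@@H](n2c(SCc3cc4cc(C)ccc4oc3=O)nc3cncnc32)[C@H](OC(C)=O)[C@@H]1OC(C)=O` gives 16000 nM.
Compound 3 `CC(=O)OC[C@H]1O[C@@H](n2c(SCc3cc4cc(Br)ccc4oc3=O)nc3cncnc32)[C@H](O)[C@@H]1O` gives 31000 nM.

All three were examined in a functional assay on Huh-5-2 cells (Homo sapiens) for cytotoxicity, read by microscopy; on this read-out lower numbers stand for higher toxicity in this test and higher numbers for lower toxicity in this test. From compound 1 to compound 2 the change is methyl in place of bromo on an aromatic carbon; the step it made was a 2.4-fold higher number from compound 1 to compound 2 (0.38 log units; beyond the scatter). Compound 3 shares the bromo substituent of compound 1, but the difference between the two cores is not broken down here; their two values show that compound 3 has the higher number, and that gap lies beyond the scatter. The values of compound 2 and compound 3 lie within the scatter of each other.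

Compound 4 `CC(=O)OC[C@H]1O[C@@H](n2c(SCc3cc4cc(C)ccc4oc3=O)nc3cncnc32)[C@H](O)[C@@H]1O` has not yet been measured in this assay. It differs from compound 3 by methyl in place of bromo on an aromatic carbon, the same change as that from compound 1 to compound 2, at the same place. The expected step is a 2.1-fold higher number from compound 3 to compound 4 (0.32 log units; beyond the scatter), set beside a 2.4-fold higher number from compound 1 to compound 2 (0.38 log units; beyond the scatter), on the reasoning that the same change on the core of compound 3 should move the number in the same direction by a similar amount, though the small number of pairs leaves this uncertain. Compound 4 is therefore estimated at 65000 nM, expected between 30000 nM and 140000 nM.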

Compound 4, half-maximal cytotoxic concentration: 16000 nM
Compound 4: middle estimate off by 4.1-fold (0.61 log units), on the high side; the whole stated range lies above it.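

Methyl in place of bromo on an aromatic carbon gives a 1.9-fold lower number from compound 3 to compound 4 (0.29 log units; within the scatter) in this assay, so on this core the change cannot be told apart from the scatter of repeated measurements. Set beside the earlier step on the other core, the result shows that the two cores do not respond alike: the same change on two cores in this assay, a 2.4-fold higher number (0.38 log units; beyond the scatter) from compound 1 to compound 2 and a 1.9-fold lower number (0.29 log units; within the scatter) from compound 3 to compound 4, 4.6-fold (0.67 log units) apart, beyond the scatter of two such steps. The change therefore did not carry over from one core to the other in this test, but two pairs cannot show why the steps differ, nor do they support a rule for the wider series.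

The compounds shown leave open how this aromatic carbon would respond to other groups, such as chloro, methoxy or an amine, and whether any of them would give steps that agree across the two cores. They also leave open whether a carboxylic acid or a longer chain at the same place would separate the cores further in this assay.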